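This account rests on a few compounds, and the source may have more. Where it says the series, first, only, none or still open, it means among the compounds named here.

Compound 1 `O=C1c2ccccc2N(COCc2ccccc2)S(=O)(=O)N1Cc1ccccc1` was examined in a functional assay on HEL cells (Homo sapiens); on this read-out lower numbers stand for higher toxicity in this test and higher numbers for lower toxicity in this test. In this assay compound 1 gives > 50 ug/mL, which is a limit of the assay rather than a measured number. Two neighbours differ from it in one place each. Compound 2 `O=C1c2ccccc2NS(=O)(=O)N1Cc1ccccc1` carries hydrogen in place of (benzyloxy)methyl on the sulfonamide nitrogen in the ring. In this assay compound 2 gives > 50 ug/mL, again a limit. Because both ends sit at the limit, the step that the two limits leave unreadable from compound 1 to compound 2 cannot be read in size. Compound 3 `O=C(OCCOCN1c2ccccc2C(=O)N(Cc2ccccc2)S1(=O)=O)c1ccccc1` carries (benzoyloxy)methyl in place of phenyl on the saturated chain carbon bound to an oxygen. In this assay compound 3 gives 17 ug/mL, and the step of an at least 2.9-fold lower number from compound 1 to compound 3 (0.46 log units; beyond the scatter) lies beyond the scatter. Overall the limit of > 50 ug/mL in this assay, at which 2 of the 3 values shown sit, shows how little of the series can be ranked.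

Compound 4 `O=C1NS(=O)(=O)N(COCc2ccccc2)c2ccccc21` is still unmeasured. It differs from compound 1 in the following counted way: hydrogen in place of benzyl on an amide-type nitrogen in a ring. The closest guide is compound 2, where removal of a benzyl-bearing group left the value at the limit, namely > 50 ug/mL. By analogy, compound 4 is expected to show a step of a number no higher from compound 1 to compound 4 (the limit leaves the size open), likely remaining at or beyond the limit. The estimate for compound 4 is 50 ug/mL, with a range from 30 ug/mL to 100 ug/mL.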

Compound 4, half-maximal cytotoxic concentration: > 50 ug/mL
Compound 4 was reported as a limit; the forecaster's own chance of this, stated with the estimate: 70%; the middle value sits exactly at the limit.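

In this assay compound 4 gives > 50 ug/mL, which is a limit and not a measured number. Among these compounds, compound 1 also sits at a limit, so no step between compound 1 and compound 4 can be read. The compounds shown leave open whether compound 1, compound 2 and compound 4 differ at all in toxicity, because most values stop at the same point: the limit of > 50 ug/mL in this assay, at which 3 of the 4 values shown sit.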